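The source may hold more compounds than are shown below. What is called first, only, known or untested is meant among the compounds shown, and "the series" means these compounds.

Of the compounds shown here, three built on a shared core have been tested in an ADME assay on MT4 cells (Homo sapiens) for cytotoxicity, read by MTT assay; on this read-out higher numbers stand for lower toxicity in this test and lower numbers for higher toxicity in this test. Compound 1, `Cc1cc(C#N)cc(C)c1Oc1ccnc(Nc2ccc(CN3CCCN(S(C)(=O)=O)CC3)cc2)n1`, gives 7850 nM in this assay. Compound 2, `Cc1cc(C#N)cc(C)c1Oc1ccnc(Nc2ccc(CN3CCN(S(=O)(=O)C(C)C)CC3)cc2)n1`, gives 4540 nM in this assay. Compound 3, `Cc1cc(/C=C/C#N)cc(C)c1Oc1ccnc(Nc2ccc(CN3CCN(S(=O)(=O)C(C)C)CC3)cc2)n1`, gives 3810 nM in this assay. Compound 4, `Cc1cc(/C=C/C#N)cc(C)c1Oc1ccnc(Nc2ccc(CN3CCCN(S(C)(=O)=O)CC3)cc2)n1`, has not yet been measured.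

Compound 2 and compound 1 differ in one place: 4-(methylsulfonyl)-1,4-diazepan-1-yl in place of 4-(isopropylsulfonyl)piperazin-1-yl on a saturated chain carbon bound to an aromatic carbon. In this assay this change gave a 1.7-fold higher number from compound 2 to compound 1 (0.24 log units; within the scatter). Compound 2 and compound 3 differ in another place: 2-cyanoethenyl in place of cyano on an aromatic carbon. In this assay this change gave a 1.2-fold lower number from compound 2 to compound 3 (0.08 log units; within the scatter). Both steps stay within the ordinary spread of repeated measurements, so neither shows a real shift between its two compounds.

Compound 4 stands to compound 3 exactly as compound 1 stands to compound 2: 4-(methylsulfonyl)-1,4-diazepan-1-yl in place of 4-(isopropylsulfonyl)piperazin-1-yl on a saturated chain carbon bound to an aromatic carbon. The place of the change is the same word for word, so it is the same change, made here on a core that carries the 2-cyanoethenyl group instead of the cyano group. Going by the values given here, the single earlier occurrence is the only guide to what it may do. For compound 4 in this assay the expected step is a 1.7-fold higher number from compound 3 to compound 4 (0.23 log units; within the scatter). Among the compounds with values here, this expectation rests on the one prior instance of the same change, which gave a 1.7-fold higher number from compound 2 to compound 1 (0.24 log units; within the scatter), a step small enough to sit within the usual spread. Compound 4 is accordingly estimated at 6500 nM, with a likely range from 3000 nM to 14000 nM.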

Compound 4, half-maximal cytotoxic concentration: 17400 nM
The estimate for compound 4 lay 2.7-fold (0.43 log units) below the measured number, outside the stated range (above it).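

In this assay, putting 4-(methylsulfonyl)-1,4-diazepan-1-yl in place of 4-(isopropylsulfonyl)piperazin-1-yl on the core with the 2-cyanoethenyl group gave a 4.6-fold higher number from compound 3 to compound 4 (0.66 log units; beyond the scatter), a clear step, whereas the same swap on the core with the cyano group stayed within the scatter, yet the two steps cannot be told apart: the same change on two cores in this assay, a 1.7-fold higher number (0.24 log units; within the scatter) from compound 2 to compound 1 and a 4.6-fold higher number (0.66 log units; beyond the scatter) from compound 3 to compound 4, 2.6-fold (0.42 log units) apart, within the scatter of two such steps

The other change reads the same way, for 2-cyanoethenyl in place of cyano gave a 2.2-fold higher number from compound 1 to compound 4 (0.35 log units; beyond the scatter) on the core with the 4-(methylsulfonyl)-1,4-diazepan-1-yl group, and its two steps cannot be told apart either: the same change on two cores in this assay, a 1.2-fold lower number (0.08 log units; within the scatter) from compound 2 to compound 3 and a 2.2-fold higher number (0.35 log units; beyond the scatter) from compound 1 to compound 4, 2.6-fold (0.42 log units) apart, within the scatter of two such steps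

Going by these compounds alone, these four compounds therefore give no sign that either change behaves differently from one core to the other, but with only one pair per core they do not prove that the steps are truly equal.

The swap alters the ring and the group on the sulfur at once, so the compounds shown leave open which of the two goes with the higher number, a question that 4-(methylsulfonyl)piperazin-1-yl or 4-(isopropylsulfonyl)-1,4-diazepan-1-yl could address. They also leave open whether the swap acts alike on a core carrying another group in place of the nitrile-bearing one, such as a chlorine atom or an amide.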